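The source may report more compounds than this note shows. Statements on the series, on what has been measured and on what is new or still open speak of the compounds shown alone.

Three compounds share one core and were tested in a functional assay on MCF7 cells (Homo sapiens) for cytotoxicity, read by MTT assay, with a stated time of 48 h; a higher number here means a weaker inhibitor, a lower number a stronger inhibitor. Compound 1 `COc1ccc(-c2cc(C(=O)Nc3nc4ccc(F)cc4s3)nc3cc(-c4ccccc4)nn23)cc1OC` gives 22400 nM, compound 2 `COc1cc(-c2cc(C(=O)Nc3nc4ccc(F)cc4s3)nc3cc(-c4ccccc4)nn23)cc(OC)c1OC` gives 27500 nM, and compound 3 `COc1ccc(-c2cc(C(=O)Nc3nc4ccc(OC)cc4s3)nc3cc(-c4ccccc4)nn23)cc1` gives 19100 nM. Between compound 2 and compound 1 the change hydrogen in place of methoxy on an aromatic carbon produced a 1.2-fold lower number from compound 2 to compound 1 (0.09 log units; within the scatter). The difference between compound 2 and compound 3 is not broken down here.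

Compound 4 `COc1ccc(-c2cc(C(=O)Nc3nc4ccccc4s3)nc3cc(-c4ccccc4)nn23)cc1` has not yet been measured in this assay. It arises from compound 3 by hydrogen in place of methoxy on an aromatic carbon. This is the same kind of change as that from compound 2 to compound 1, but its surroundings differ: there the place was ortho to a methoxy group, meta to a large group and meta to a methoxy group, whereas here it is part of a fused system of two rings, meta and para to a fused ring. Since the earlier step stayed within the scatter, the step of a 1.1-fold lower number from compound 3 to compound 4 (0.05 log units; within the scatter) is expected to be similarly small. Compound 4 is estimated at 17000 nM, between 7000 nM and 40000 nM.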

Compound 4, half-maximal inhibitory concentration: 2230 nM
Beside the measured number, compound 4's estimate is 7.6-fold (0.88 log units) above it; the measured number lies below the stated range.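

In this assay, hydrogen in place of methoxy on the benzothiazole part gave an 8.6-fold lower number from compound 3 to compound 4 (0.93 log units; beyond the scatter), and this step does not match the one seen earlier on the other core: the same change on two cores in this assay, a 1.2-fold lower number (0.09 log units; within the scatter) from compound 2 to compound 1 and an 8.6-fold lower number (0.93 log units; beyond the scatter) from compound 3 to compound 4, 7.0-fold (0.84 log units) apart, beyond the scatter of two such steps. This shows that, in this series, the size of this change cannot be carried from one core to another, since a step within the scatter on one core did not predict the step on the other. It does not show whether the place of the change or the rest of the core accounts for the gap, and two pairs establish no general rule.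

The compounds shown leave open how a hydroxy, ethoxy or amino group at that same place would compare with methoxy and hydrogen. They also leave open whether the step from 6-methoxy-1,3-benzothiazol-2-yl to 1,3-benzothiazol-2-yl keeps its size with other groups on the shared core.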